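The source may hold more compounds than are shown below. What is called first, only, known or untested is meant among the compounds shown, and "the series" means these compounds.

Measured so far:
- Compound 1 `COc1cccc(/C=C2\CCC/C(=C\c3cccc(Br)c3)C2=O)c1OC`: 23900 nM
- Compound 2 `COc1ccc(/C=C2\CCC/C(=C\c3cccc(OC)c3OC)C2=O)cc1OC`: 14900 nM
- Compound 3 `COc1cccc(/C=C2\CCC/C(=C\c3ccc(OC)c(OC)c3)C2=O)c1`: 11600 nM

In an ADME assay on NHDF cells (Homo sapiens) for cytotoxicity, read by MTT assay, with a stated time of 72 h (on this read-out higher numbers stand for weaker inhibition and lower numbers for stronger inhibition), compound 3 gives 11600 nM, which lies within the scatter of compound 2 at 14900 nM. Compound 1, at 23900 nM, carries a higher number than compound 3, and that gap is beyond the scatter.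

Compound 4 `COc1ccc(/C=C2\CCC/C(=C\c3cc(Cl)cc(Cl)c3)C2=O)cc1OC` departs from compound 3 by one change: 3,5-dichlorophenyl in place of 3-methoxyphenyl on a double-bonded chain carbon bound to a double-bonded ring carbon.

Among the measured compounds shown here, only one measured step links two compounds that differ in one place, a 1.3-fold lower number from compound 2 to compound 3 (0.11 log units; within the scatter). It removes a methoxy and stays within the scatter, and it does not exchange one ring substituent pattern for a dichlorinated one. For the measured compounds named here, compound 1 is the only measured compound carrying halogen, and at 23900 nM it offers a weak hint of a higher number, though it differs from compound 3 in more than one place. A small rise is therefore expected in this assay, probably not beyond the scatter. The estimated step is a 1.3-fold higher number from compound 3 to compound 4 (0.11 log units; within the scatter). The estimate for compound 4 is 15000 nM, with an expected range of 6000 nM to 35000 nM.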

Compound 4, half-maximal inhibitory concentration: 8300 nM
Compound 4: the middle estimate sits 1.8-fold (0.26 log units) above what was measured, within the range that was stated.
By their numbers in this assay, from the lowest: compounds 4, 3, 2 and 1 (each within the scatter of the next, the first and the last beyond it).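

In this assay, the exchange of 3-methoxyphenyl for 3,5-dichlorophenyl on a double-bonded chain carbon bound to a double-bonded ring carbon gives a 1.4-fold lower number from compound 3 to compound 4 (0.15 log units; within the scatter). Among the compounds shown here, this is the first single-place step in which a whole substituted ring is swapped, with chlorine replacing the methoxy oxygen, and the number stays within the scatter, so this position accepts that exchange without a clear shift in this read-out. Nothing measured on these compounds offers an explanation for this result.

The compounds shown leave open whether a single chlorine would behave like the pair of chlorines in compound 4. They also leave open whether an amine or a carboxylic acid on that aromatic ring would carry the number beyond the scatter.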